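Bromo for Methoxy on the Urea Aryl Ring

The source may hold more compounds than are shown below. What is called first, only, known or untested is meant among the compounds shown, and "the series" means these compounds.

Of the compounds shown here, two have been measured in an assay on isolated protein for inhibition of serine/threonine-protein kinase PAK 1 (Homo sapiens), read by ADP-Glo, with a stated time of 40 min (a higher number here means a weaker inhibitor, a lower number a stronger inhibitor), so far. Compound 1 `O=C(NC1CCN(c2ncnc3[nH]ncc23)CC1)c1ccc(Br)cc1` is an amide, and in this assay compound 1 gives 16400 nM. Compound 2 `COc1ccc(NC(=O)NC2CCN(c3ncnc4[nH]ncc34)CC2)cc1` is a urea, and in this assay compound 2 gives 6370 nM. Going by the values given here, compound 2 therefore has the lowest number of the two, and the one step recorded, a 2.6-fold lower number from compound 1 to compound 2 (0.41 log units; beyond the scatter), was judged modest but beyond the scatter.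

Compound 3 `O=C(Nc1ccc(Br)cc1)NC1CCN(c2ncnc3[nH]ncc23)CC1` is the next one to be measured. It differs from compound 2 in a single place: bromo in place of methoxy on an aromatic carbon, on an aromatic carbon of a six-membered aromatic ring of carbon only, para to a large group. Compound 3 thus keeps the urea of compound 2 but carries the bromo of compound 1, so it separates the two things that changed together in the step from compound 1 to compound 2. Among the compounds with values here, only that one step bears on the question, and it mixed both changes, so the expected size of a 1.5-fold higher number from compound 2 to compound 3 (0.17 log units; within the scatter) is uncertain and most likely a loss of modest size. On that basis compound 3 is estimated at 9500 nM, with a range from 4000 nM to 25000 nM.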

Compound 3, half-maximal inhibitory concentration: 4030 nM
Estimate against measurement, compound 3: 2.4-fold (0.37 log units) above, within the range that was stated.
By their numbers in this assay, from the lowest: compounds 3 and 2 (each within the scatter of the next); then compound 1.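

With the urea held fixed, bromo in place of methoxy on an aromatic carbon, para to a large group, gives a 1.6-fold lower number from compound 2 to compound 3 (0.20 log units; within the scatter), so this assay does not tell these two groups apart at this position. With the 4-bromophenyl group held fixed, (4-bromophenyl)amino in place of 4-bromophenyl on a carbonyl carbon turns the amide into the urea and gives a 4.1-fold lower number from compound 1 to compound 3 (0.61 log units; beyond the scatter); this separates the linker change from the ring substituent change, which were mixed in the earlier step, and only the linker change gives a step beyond the scatter. No measurement is available to explain either result.

The compounds shown leave open how other groups at this ring position, such as fluoro, a nitrile or a carboxylic acid, would compare with bromo and methoxy. They also leave open whether methoxy and bromo would still read alike on the amide, and whether a methylene in place of the urea amino link would keep the number seen for the urea.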